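From 2-methylphenyl to 2-ethylphenyl

This account rests on a few compounds, and the source may have more. Where it says the series, first, only, none or still open, it means among the compounds named here.

Of the compounds shown here, two with the same core have been measured in an ADME assay (liver) for metabolic stability, with Liver microsome (Homo sapiens) as the target, read by LC-MS, using microsomes, with a stated time of 30 min, tested at 4 uM; on this read-out lower numbers stand for a less stable compound and higher numbers for a more stable compound. Compound 1 `COc1cccc(-c2nc3c(N4CCN(C)CC4)nc(C)nc3n2C2CCOCC2)c1` gives 40%, while compound 2 `Cc1nc(N2CCN(C)CC2)c2nc(-c3ccccc3C)n(C3CCOCC3)c2n1` gives 18%, the lower of the two numbers. Within the data shown here, the only measured step is a number 22 percentage points lower from compound 1 to compound 2 (beyond the scatter), and it comes with 2-methylphenyl in place of 3-methoxyphenyl on an aromatic carbon.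

Compound 3 `CCc1ccccc1-c1nc2c(N3CCN(C)CC3)nc(C)nc2n1C1CCOCC1` has not yet been measured in this assay. It differs from compound 2 by methyl in place of hydrogen on a saturated chain carbon bound to an aromatic carbon, so that 2-methylphenyl becomes 2-ethylphenyl. Among the measured compounds shown here, the measured step bears on this only indirectly, since it exchanged a different group and no measured pair shows this change itself. For the measured compounds named here, the structural change is also smaller than the one in that step, so a step of similar size is not expected. With compound 2 at 18% as the starting point, only a slight fall, within the scatter, is expected. The expected step is a number 3 percentage points lower from compound 2 to compound 3 (within the scatter). For compound 3 the estimated value is 15%, with an expected range from 5% to 28%.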

Compound 3, percent of the compound remaining: 33%
Compound 3: the middle estimate sits 18 percentage points below what was measured; measured number above the stated range.
By their numbers in this assay, from the lowest: compound 2; then compounds 3 and 1 (each within the scatter of the next).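

In this assay, methyl in place of hydrogen on a saturated chain carbon bound to an aromatic carbon is not a silent change (a number 15 percentage points higher from compound 2 to compound 3 (beyond the scatter)), so a single added carbon at this place is enough to move the read-out beyond the scatter. The earlier step (a number 22 percentage points lower from compound 1 to compound 2 (beyond the scatter)) might have suggested that 3-methoxyphenyl holds an advantage over an alkyl-substituted phenyl, but 2-ethylphenyl shows no such gap (a number 7 percentage points lower from compound 1 to compound 3 (within the scatter)), and compound 1 and compound 3 cannot be told apart on this read-out. Nothing given here accounts for why 2-ethylphenyl and 2-methylphenyl differ in this way.

The compounds shown leave open whether the number keeps rising with a longer chain such as propyl on this carbon, or whether a branched group such as isopropyl behaves like ethyl. From the compounds shown here alone, the effect of the added methyl also rests on a single pair, so whether it would hold with other groups on the shared core remains unknown.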